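The source may report more compounds than this note shows. Statements on the series, on what has been measured and on what is new or still open speak of the compounds shown alone.

Compounds and values in an assay (Rattus norvegicus) for inhibition of Fatty-acid amide hydrolase 1 (Homo sapiens); on this read-out higher numbers stand for weaker inhibition and lower numbers for stronger inhibition: compound 1 `Nc1cccc(-c2cnc(C(=O)CCCCCCc3ccccc3)o2)c1` gives 19 nM; compound 2 `COC(=O)c1cccc(-c2cnc(C(=O)CCCCCCc3ccccc3)o2)c1` gives 12 nM; compound 3 `O=C(CCCCCCc1ccccc1)c1ncc(-c2cccc(O)c2)o1` gives 50 nM.

Compound 3 stands highest of the three, with a 2.6-fold higher number from compound 1 to compound 3 (0.42 log units; beyond the scatter) and a 4.2-fold higher number from compound 2 to compound 3 (0.62 log units; beyond the scatter) placing it beyond the scatter from both others. Compound 4 `O=C(CCCCCCc1ccccc1)c1ncc(-c2cccc(C(=O)C(F)(F)F)c2)o1` carries (trifluoromethyl)carbonyl in place of hydroxy on an aromatic carbon. Going by the values given here, the step that bears on this is the one between compound 2 and compound 3, where a 4.2-fold higher number from compound 2 to compound 3 (0.62 log units; beyond the scatter) shows that a carbonyl-bearing group in that place went with a lower number than hydroxy. On that basis a lower number is expected for compound 4, estimated as a 3.8-fold lower number from compound 3 to compound 4 (0.59 log units; beyond the scatter). Compound 4 is thus estimated at 13 nM, with a range from 4 nM to 40 nM.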

Compound 4, inhibition constant: 16 nM
The estimate for compound 4 lay 1.2-fold (0.09 log units) below the measured number; measured number inside the range.
By their numbers in this assay, from the lowest: compounds 2, 4 and 1 (each within the scatter of the next); then compound 3.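

In this assay, (trifluoromethyl)carbonyl on this aromatic carbon clearly separates from hydroxy (a 3.1-fold lower number from compound 3 to compound 4 (0.49 log units; beyond the scatter)), which extends the earlier contrast with methoxycarbonyl to a second carbonyl-bearing group. It cannot be told apart from methoxycarbonyl (a 1.3-fold higher number from compound 2 to compound 4 (0.12 log units; within the scatter)) or from amino (a 1.2-fold lower number from compound 1 to compound 4 (0.07 log units; within the scatter)), so among these four groups only the hydroxy of compound 3 stands apart. No measurement offered here explains this.

On these data alone, whether a carboxylic acid, an amide or a nitrile at this place would stay level with compound 1, compound 2 and compound 4 remains open. Also open, as far as these compounds go, is whether this ranking would hold with a shorter or longer chain on the ketone.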